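The compounds below may be only part of what the source reports. "The series", "measured", "known", "first", "only" and "open" are said of these compounds alone.

In a functional assay on A549 cells (Homo sapiens) for antiproliferative activity, read by MTT assay, with a stated time of 48 h (a lower number here means a stronger inhibitor, a higher number a weaker inhibitor), three compounds sharing one core have been measured. Compound 1 `COc1ccc(/C=C/c2cc(OC)cc(OC)c2/C=C/C(=O)c2cccc(Cl)c2)cc1` gives 5.6 ug/mL, compound 2 `COc1ccc(/C=C/c2cc(OC)cc(OC)c2/C=C/C(=O)c2ccc(N)cc2)cc1` gives 3.8 ug/mL, and compound 3 `COc1ccc(/C=C/c2cc(OC)cc(OC)c2/C=C/C(=O)c2ccc(OC)cc2)cc1` gives 4.5 ug/mL, so compound 3 stands within the usual scatter of both others. Compound 4 `COc1ccc(/C=C/c2cc(OC)cc(OC)c2/C=C/C(=O)c2ccc(C)c(C)c2)cc1` alters one group: 3,4-dimethylphenyl in place of 4-methoxyphenyl on a carbonyl carbon. Three measured swaps on this end of the molecule bear on it: a 1.5-fold lower number from compound 1 to compound 2 (0.17 log units; within the scatter), a 1.2-fold lower number from compound 1 to compound 3 (0.09 log units; within the scatter) and a 1.2-fold higher number from compound 2 to compound 3 (0.07 log units; within the scatter). Each stayed within the scatter, so no step beyond it is expected, in either direction. The expected step is small: no change at the digits printed from compound 3 to compound 4 (within the scatter). For compound 4 the estimated value is 4.5 ug/mL, with an expected range of 2.4 ug/mL to 8 ug/mL.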

Compound 4, half-maximal inhibitory concentration: 0.1 ug/mL
Estimate against measurement, compound 4: 45-fold (1.65 log units) above; the whole stated range lies above it.
By their numbers in this assay, from the lowest: compound 4; then compounds 2, 3 and 1 (each within the scatter of the next).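

In this assay, going by these compounds alone, the group on the carbonyl carbon can matter far more than the earlier compounds suggested: 3,4-dimethylphenyl gives large steps from all three others (a 45-fold lower number from compound 3 to compound 4 (1.65 log units; beyond the scatter); a 38-fold lower number from compound 2 to compound 4 (1.58 log units; beyond the scatter); a 56-fold lower number from compound 1 to compound 4 (1.75 log units; beyond the scatter)). The earlier aryl groups stayed within the scatter of one another, so compound 4 alone stands apart, as the strongest of the four. No measurement shown here explains this gain.

From the compounds shown here alone, it remains open whether both methyl groups of 3,4-dimethylphenyl are needed. Going by these compounds, it is also open whether ethyl groups or chlorine atoms in their place would keep the gain.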